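A few compounds are considered here, and "the series" means these few. Any claim that something is new, unique, unknown or untested is made for them only; others in the source may bear on it.

Notes on the series. Two compounds have been run in an ADME assay on microsomes from liver (Mus musculus) for metabolic stability, read by LC-MS, using NADPH, with a stated time of 45 min, tested at 0.5 uM; a higher number here means faster removal of the compound, a lower number slower removal. Among the compounds with values here, compound 2 `CCN(CC)C(=O)CCSc1nc2cc(Cl)ccc2o1` gives 108 mL/min/g, the higher of the two numbers measured so far. Compound 1 `CS(=O)(=O)C1CCN(C(=O)CCSc2nc3cc(Cl)ccc3o2)C1`, which carries a different amide substituent, gives 2.1 mL/min/g in this assay, and the gap between compound 1 and compound 2 lies well beyond the usual scatter. Within the data shown here, no step between compounds differing in one place is available, so what the change in the amide brings cannot be read from the data directly.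

The next compound, compound 3 `CC1CCN(C(=O)CCSc2nc3cc(Cl)ccc3o2)C1`, differs from compound 2 in one place only: 3-methylpyrrolidin-1-yl in place of diethylamino on a carbonyl carbon. Among the measured compounds shown here, a cyclic amine replaces an open-chain one, but the data give no step of that kind to lean on. The step from compound 2 to compound 3 in this assay is expected to be small, a 1.4-fold lower number from compound 2 to compound 3 (0.16 log units; within the scatter), if anything downward, and within or near the scatter. For compound 3 the estimate in this assay is 75 mL/min/g, with a range from 25 mL/min/g to 200 mL/min/g.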

Compound 3, intrinsic clearance in a liver preparation (reported as CLH), per the amount of preparation that the assay uses: 90.7 mL/min/g
Estimate against measurement, compound 3: 1.2-fold (0.08 log units) below, and the stated range covers the measured number.
By their numbers in this assay, from the lowest: compound 1; then compounds 3 and 2 (each within the scatter of the next).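

In this assay the change from diethylamino to 3-methylpyrrolidin-1-yl on a carbonyl carbon gives a 1.2-fold lower number from compound 2 to compound 3 (0.08 log units; within the scatter) and so stays within the scatter: in this pair, closing the open-chain amine into a five-membered ring leaves the read-out unmoved. The single-place step on the saturated ring carbon is of another order: methyl in place of methylsulfonyl gives a 43-fold higher number from compound 1 to compound 3 (1.64 log units; beyond the scatter) and so ties the large gap in the series to that one group on the ring, which the earlier pair, differing in the whole amide substituent, could not do.

As far as these compounds go, whether a hydroxyl, a carboxylic acid, a primary amine or the unsubstituted pyrrolidine at that ring carbon would fall nearer compound 1 or compound 3 remains open. Nothing at hand accounts for either step.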